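The compounds below may be only part of what the source reports. "The series", "measured", "known", "first", "only" and "open" are said of these compounds alone.

In an assay on isolated protein for inhibition of Dihydrofolate reductase (Homo sapiens), read by spectrophotometry (a higher number here means a weaker inhibitor, a lower number a stronger inhibitor), compound 2 `CN(Cc1nc2cc(C(F)(F)F)ccc2nc1-c1ccccc1)c1ccc(OC(F)(F)F)cc1` gives 3000 nM. Compound 1 `CN(Cc1nc2cc(C(F)(F)F)ccc2nc1-c1ccccc1)c1ccc(F)cc1` gives 5000 nM in this assay, and the change from fluoro to trifluoromethoxy on the aryl ring reads a 1.7-fold lower number from compound 1 to compound 2 (0.22 log units; within the scatter), so the two values sit within the scatter of each other. Compound 3 `C#CCN(Cc1nc2cc(C(F)(F)F)ccc2nc1-c1ccccc1)c1ccc(OC(F)(F)F)cc1` differs from compound 2 by ethynyl in place of hydrogen on a saturated chain carbon bound to a nitrogen on an aromatic ring. Within the data shown here, no measured step touches the chain on the aniline nitrogen, so there is no basis for expecting a shift beyond the scatter. For compound 3 the expected result in this assay is 3000 nM, with a range from 1000 nM to 9000 nM, a step estimated as no change at the digits printed from compound 2 to compound 3 (within the scatter).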

Compound 3, inhibition constant: 4000 nM
Compound 3: middle estimate off by 1.3-fold (0.12 log units), on the low side, within the range that was stated.
By their numbers in this assay, from the lowest: compounds 2, 3 and 1 (each within the scatter of the next).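

In this assay, among these compounds, methyl to propargyl gives a 1.3-fold higher number from compound 2 to compound 3 (0.12 log units; within the scatter) and is the first change read on the saturated chain carbon bound to a nitrogen on an aromatic ring. Among the compounds shown here, at this position, ethynyl in place of hydrogen thus brings no shift beyond the scatter in the one pair available, with trifluoromethoxy on the aryl ring. No measured evidence bears on this result. Still open, from the compounds shown here alone, is whether a longer chain, an amine or a carboxylic acid at this position would move the number beyond the scatter. Also open, going by these compounds, is whether propargyl reads the same alongside fluoro on the aryl ring.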